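Moving a Methyl Group Around an Amide-Linked Phenyl Ring

The source may hold more compounds than are shown below. What is called first, only, known or untested is meant among the compounds shown, and "the series" means these compounds.

Compound 2 `COc1cc(-c2cc(C(=O)O)c3ccccc3n2)ccc1OCC(=O)Nc1cccc(C)c1` is one of two closely related acids tested in an ADME assay on HaCaT cells (Homo sapiens) for inhibition; on this read-out lower numbers stand for stronger inhibition and higher numbers for weaker inhibition. Compound 2 gives 225000 nM, the only outright number among the two results shown. Compound 1 `COc1cc(-c2cc(C(=O)O)c3ccccc3n2)ccc1OCC(=O)Nc1ccccc1` gives > 300000 nM, which is a limit of the assay rather than a number. Going by the values given here, the single measured step, an at least 1.3-fold lower number from compound 1 to compound 2 (0.12 log units; that floor lies within the scatter), is bounded only by the limit of > 300000 nM in this assay, at which 1 of the 2 values shown sits, so its true size is not known. Compound 3 `COc1cc(-c2cc(C(=O)O)c3ccccc3n2)ccc1OCC(=O)Nc1ccc(C)cc1` differs from compound 2 only by 4-methylphenyl in place of 3-methylphenyl on an amide-type nitrogen. Among the compounds with values here, no measured step describes moving a methyl group from one place to another on this ring, so the change from compound 2 to compound 3 is expected to stay within the scatter, with an estimated step of a 1.1-fold higher number from compound 2 to compound 3 (0.03 log units; within the scatter). Compound 3 is therefore estimated to give 240000 nM in this assay, with an expected range from 120000 nM to 480000 nM.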

Compound 3, half-maximal inhibitory concentration: > 300000 nM
Compound 3: only a limit was reported; the forecaster's own chance of this, stated with the estimate: 35%; middle value at least 1.2-fold (0.09 log units) away from the limit.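

Moving the methyl group from 3-methylphenyl to 4-methylphenyl on the amide-type nitrogen gives an at least 1.3-fold higher number from compound 2 to compound 3 (0.12 log units; that floor lies within the scatter), so this change of ring position in this assay has no effect that can be told apart from the scatter, though its true size may be larger. Adding a methyl group to the ring does not by itself yield an outright number, as compound 3 carries one and still ends at a limit of the assay. Compound 1 and compound 3 both rest on a limit, so the step between them cannot be read, and the same limit leaves the size of the other steps open: the limit of > 300000 nM in this assay, at which 2 of the 3 values shown sit.

Still open, on these data alone, is whether a different group on this phenyl ring, such as a chlorine atom or an amine, would give an outright number in this assay. Whether such a group would respond to its ring position is equally unknown.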